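The compounds below may be only part of what the source reports. "The series", "measured", "known", "first", "only" and "open" are said of these compounds alone.

The measured compounds and their readings:

Compound 1, `COc1cccc(S(=O)(=O)c2cnc3ccc(Cl)cc3c2N2CCC(C)CC2)c1`: in an assay on isolated protein for displacement of a labelled ligand from metabotropic glutamate receptor 5 (Homo sapiens), with a stated time of 60 min, tested at 1 uM (a lower number here means less inhibition, a higher number more inhibition at the concentration tested (going by the name of the read-out)), compound 1 gives 87%.
Compound 2, `COc1ccc(S(=O)(=O)c2cnc3ccc(Cl)cc3c2N2CCC(C)CC2)cc1Cl`: compound 2 gives 46%.
Compound 3, `COc1ccc2ncc(S(=O)(=O)c3ccc(OC)c(Cl)c3)c(N3CCC(C)CC3)c2c1`: compound 3 gives 21%.

All three share a core carrying a sulfonyl group that links to a second aromatic ring, and the two differences among them are small swaps of groups. Going from compound 2 to compound 1, the change is 3-methoxyphenyl in place of 3-chloro-4-methoxyphenyl on a sulfonyl sulfur, and it brought a large rise: a number 41 percentage points higher from compound 2 to compound 1 (beyond the scatter). Going from compound 2 to compound 3, the change is methoxy in place of chloro on an aromatic carbon, and it lowered the reading: a number 25 percentage points lower from compound 2 to compound 3 (beyond the scatter). Compound 3 therefore has the lowest reading of the three.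

Compound 4, `COc1cccc(S(=O)(=O)c2cnc3ccc(OC)cc3c2N2CCC(C)CC2)c1`, has not been measured. Among the compounds with values here, it differs from compound 3 by 3-methoxyphenyl in place of 3-chloro-4-methoxyphenyl on a sulfonyl sulfur, which is the same change as the one from compound 2 to compound 1, made at the same place. The two cores differ, as described by methoxy in place of chloro on an aromatic carbon.

For compound 4 in this assay, a rise of about the same size is expected, because the earlier swap gave a number 41 percentage points higher from compound 2 to compound 1 (beyond the scatter); the estimated step is a number 37 percentage points higher from compound 3 to compound 4 (beyond the scatter). Within the data shown here, with only one prior example, the expected reading for compound 4 is 58%, estimated to fall between 32% and 82%.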

Compound 4, a percentage reported as inhibition, at one concentration (the size of the read-out at that concentration, not a potency): 0%
Estimate against measurement, compound 4: 58 percentage points above, outside the stated range (below it).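

In this assay, the swap to 3-methoxyphenyl on a sulfonyl sulfur gave a number 21 percentage points lower from compound 3 to compound 4 (beyond the scatter), so the rise seen on the core of compound 2 did not carry over to the core of compound 3, and the direction reversed: the same change on two cores in this assay, a number 41 percentage points higher (beyond the scatter) from compound 2 to compound 1 and a number 21 percentage points lower (beyond the scatter) from compound 3 to compound 4, 62 percentage points apart, beyond the scatter of two such steps The other change, methoxy in place of chloro on an aromatic carbon, kept its direction but not its size, giving a number 87 percentage points lower from compound 1 to compound 4 (beyond the scatter), a much larger fall than the one seen with 3-chloro-4-methoxyphenyl on the sulfonyl sulfur: the same change on two cores in this assay, a number 25 percentage points lower (beyond the scatter) from compound 2 to compound 3 and a number 87 percentage points lower (beyond the scatter) from compound 1 to compound 4, 62 percentage points apart, beyond the scatter of two such steps Across these four compounds, then, the effect of each change depends on the group at the other place, so a step seen on one core cannot simply be transferred to the other, but the readings do not show why this happens, and four compounds give no rule for the wider series.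

The compounds shown leave open whether the same dependence appears with a fluoro or methyl group in place of the chloro or methoxy on the core. Also open, on these data alone, is how a plain phenyl on the sulfonyl sulfur would read on either core.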